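A few compounds are considered here, and "the series" means these few. Any claim that something is new, unique, unknown or untested is made for them only; others in the source may bear on it.

Series values in a functional assay on Raji cells (Homo sapiens) for cytotoxicity, read by CCK-8 assay, with a stated time of 24 h; on this read-out lower numbers stand for stronger inhibition and higher numbers for weaker inhibition:
- compound 1 `C=CC(=O)N1C(=O)CC(c2ccc(OC)cc2)Sc2ccccc21`: 43300 nM
- compound 2 `C=CC(=O)N1C(=O)CCSc2ccccc21`: 581000 nM
- compound 3 `C=CC(=O)N1C(=O)CC(c2cccc(Cl)c2)Sc2ccccc21`: 47100 nM

Compound 1 sits at the low end of these three numbers, but it is not separated from its nearest neighbour: a 1.1-fold higher number from compound 1 to compound 3 (0.04 log units; within the scatter). The furthest value is well apart: a 13-fold higher number from compound 1 to compound 2 (1.13 log units; beyond the scatter).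

Compound 4 `C=CC(=O)N1C(=O)CC(c2ccc(C(=O)OC)cc2)Sc2ccccc21` keeps the core of compound 1 and differs as follows: methoxycarbonyl in place of methoxy on an aromatic carbon. This is methoxycarbonyl in place of methoxy on an aromatic carbon, para to a large group.

The large steps, a 13-fold higher number from compound 1 to compound 2 (1.13 log units; beyond the scatter) and a 12-fold lower number from compound 2 to compound 3 (1.09 log units; beyond the scatter), concern losing or gaining the whole aryl group, which compound 4 retains. The closer precedent is an exchange of one substituted phenyl for another, and there compound 3 at 47100 nM stays level with compound 1. This is a single exchange, and no ester has been measured in the series, so the range is kept wide.

The expected result is no change beyond the scatter, with an estimated 1.0-fold higher number from compound 1 to compound 4 (0.02 log units; within the scatter). For compound 4 the estimated value in this assay is 45000 nM, with an expected range of 22000 nM to 95000 nM.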

Compound 4, half-maximal inhibitory concentration: 89600 nM
Compound 4: middle estimate off by 2.0-fold (0.30 log units), on the low side, and the stated range covers the measured number.
By their numbers in this assay, from the lowest: compounds 1, 3 and 4 (each within the scatter of the next, the first and the last beyond it); then compound 2.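

At the aromatic carbon para to a large group, methoxycarbonyl in place of methoxy gives a step beyond the scatter in this assay: a 2.1-fold higher number from compound 1 to compound 4 (0.32 log units; beyond the scatter). The substituent on the aryl group can therefore shift the number, whereas the exchange of one substituted phenyl for another in a 1.1-fold higher number from compound 1 to compound 3 (0.04 log units; within the scatter) stayed within the scatter. The shift remains modest beside the loss of the whole aryl group in a 13-fold higher number from compound 1 to compound 2 (1.13 log units; beyond the scatter), and no measurement at hand accounts for it.

As far as these compounds go, it remains open whether this step is specific to the ester or would follow other replacements of methoxy, which a carboxylic acid or an amine on the same carbon would help to separate. A longer chain on the ester, such as ethoxycarbonyl, would show whether the number keeps rising with the size of this group.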